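The compounds below may be only part of what the source reports. "The series", "measured", "known", "first", "only" and "open" are said of these compounds alone.

Compound 1 `O=C(CN1CCC(c2cccc[n+]2[O-])CC1)Nc1cccc(F)c1` is the reference point here. In a functional assay on HEK293 cells for agonist activity at D(4) dopamine receptor (Homo sapiens), read by FLIPR (a lower number here means a smaller maximal response, a higher number a larger maximal response), compound 1 gives 70%, the highest of the three numbers measured. Compound 3 `CC(C)Oc1cccc(NC(=O)CN2CCC(c3cccc[n+]3[O-])CC2)c1` gives 48% in this assay, and compound 2 `O=C(CN1CCC(c2ccccn2)CC1)Nc1c(Cl)cc(Cl)cc1Cl` gives 45%; both sit beyond the scatter below compound 1.

Compound 4 `O=C(CN1CCC(c2cccc[n+]2[O-])CC1)Nc1cc(Cl)cc(Cl)c1` is not yet measured. It differs from compound 1 in one place: 3,5-dichlorophenyl in place of 3-fluorophenyl on an amide-type nitrogen.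

Going by the values given here, only one measured step bears directly on this: a number 22 percentage points lower from compound 1 to compound 3 (beyond the scatter), where the same fluoro was replaced on the same ring. That step was modest but beyond the scatter, and downward. Compound 2, which carries chlorines on its amide-bound ring together with a different pyridine-type core, also shows a lower number than compound 1, though with two changes at once no single step can be read from it. A downward step of similar, modest size is therefore expected for compound 4, as a number 20 percentage points lower from compound 1 to compound 4 (beyond the scatter). Compound 4 is estimated at 50%, within a range from 35% to 65%.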

Compound 4, largest response reached (reported as efficacy), in percent of the reference or control that the assay uses: 68%
Estimate against measurement, compound 4: 18 percentage points below, outside the stated range (above it).
By their numbers in this assay, from the lowest: compounds 2 and 3 (each within the scatter of the next); then compounds 4 and 1 (each within the scatter of the next).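

In this assay the change to 3,5-dichlorophenyl on the amide-type nitrogen gives a number 2 percentage points lower from compound 1 to compound 4 (within the scatter) and so leaves the maximal response in place. Set beside the earlier isopropoxy change, which gave a number 22 percentage points lower from compound 1 to compound 3 (beyond the scatter), this shows that replacing the 3-fluorophenyl group does not by itself lower the response: the outcome depends on what enters. No measurement at hand explains why these two changes end so differently.

Whether both chlorines are needed for this result stays open, as a phenyl ring with a single chlorine is not among the compounds shown. Also open is how the response would change with an amine or a carboxylic acid on this ring, groups that none of these compounds carries.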